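Trimming the Propargyl Amide Substituent to Ethyl

The compounds below may be only part of what the source reports. "The series", "measured", "known", "first", "only" and "open" are said of these compounds alone.

Compound 1, `C#CCN(Cc1ccc2nc(C)nc(O)c2c1)c1ccc(C(=O)N[C@@H](CCC(=O)O)C(=O)N2CCCC2C(=O)O)cc1`, in a functional assay for inhibition, with Mus musculus as the target (on this read-out lower numbers stand for stronger inhibition and higher numbers for weaker inhibition), compound 1 gives 10000 nM. Compound 2, `C#CCN(Cc1cc2c(O)nc(C)nc2cc1C)c1ccc(C(=O)N[C@@H](CCC(=O)O)C(=O)N(C)[C@@H](CCC(=O)O)C(=O)O)c(F)c1`, gives 1400 nM. Compound 3, `C#CCN(Cc1cc2c(O)nc(C)nc2cc1C)c1ccc(C(=O)N[C@@H](CCC(=O)O)C(=O)N(CC#C)[C@@H](CCC(=O)O)C(=O)O)c(F)c1`, gives 570 nM.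

Compound 3 shows the lowest number of the three measured compounds. The step of a 2.5-fold lower number from compound 2 to compound 3 (0.39 log units; beyond the scatter) separates it from its nearest neighbour, and compound 1 sits far higher still, with a number that is beyond the scatter of compound 3.

Compound 4, `C#CCN(Cc1cc2c(O)nc(C)nc2cc1C)c1ccc(C(=O)N[C@@H](CCC(=O)O)C(=O)N(CC)[C@@H](CCC(=O)O)C(=O)O)c(F)c1`, is the next candidate. It differs from compound 3 in one place: methyl in place of ethynyl on a saturated chain carbon bound to an amide-type nitrogen. Cut one bond further out, the same difference reads propargyl to ethyl.

Within the data shown here, only one measured step bears on this change. In a 2.5-fold lower number from compound 2 to compound 3 (0.39 log units; beyond the scatter), adding ethynyl on that saturated chain carbon bound to an amide-type nitrogen lowered the number modestly. Compound 4 keeps part of that addition but drops the ethynyl, so it lies between compound 2 and compound 3 in structure. A small rise in the number, possibly within the scatter, is therefore expected for compound 4, giving an estimated step of a 1.6-fold higher number from compound 3 to compound 4 (0.20 log units; within the scatter). The estimate for compound 4 is 900 nM, with a range from 400 nM to 2000 nM.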

Compound 4, half-maximal inhibitory concentration: 220 nM
For compound 4 the middle estimate is 4.1-fold (0.61 log units) above the measured one, outside the stated range (below it).
By their numbers in this assay, from the lowest: compound 4; then compound 3; then compound 2; then compound 1.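

In this assay, the ethynyl group on the saturated chain carbon bound to an amide-type nitrogen proves unnecessary for a low number: putting methyl in its place gives a 2.6-fold lower number from compound 3 to compound 4 (0.41 log units; beyond the scatter), so propargyl to ethyl improves on compound 3 and does not give back its gain. Methyl in place of hydrogen at that same carbon gives a 6.4-fold lower number from compound 2 to compound 4 (0.80 log units; beyond the scatter), which shows that this position offers more than the earlier compounds revealed, while compound 3 goes against any simple trend of lower numbers with a longer substituent. No measurement here explains why the ethyl compound reads lowest.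

A propyl chain or a chain ending in a hydroxyl group or an amine at this position remains an open test of how far the trend runs. Whether ethyl keeps its advantage on the core of compound 1 is also unknown.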